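The source may hold more compounds than are shown below. What is called first, only, known or untested is meant among the compounds shown, and "the series" means these compounds.

Compound 1 `CCCNc1[nH]c(C)nc2nccc1-2` is one of two measured compounds. In a functional assay on the whole organism for inhibition, with Nicotiana tabacum as the target (on this read-out higher numbers stand for weaker inhibition and lower numbers for stronger inhibition), compound 1 gives 339000000 nM, while compound 2 `CCC(C)Nc1[nH]c(C)nc2nccc1-2` gives 174000000 nM, the two numbers lying within the scatter of each other. Among the measured compounds shown here, the single measured step, a 1.9-fold lower number from compound 1 to compound 2 (0.29 log units; within the scatter), is the only guide available. Compound 3 `CCCCCCCCNc1[nH]c(C)nc2nccc1-2` differs from compound 1 by pentyl in place of hydrogen on a saturated chain carbon, three bonds along the chain from a nitrogen on an aromatic ring, a larger extension of the same chain than the methyl of compound 2. On that thin evidence a somewhat lower number is expected, a 2.3-fold lower number from compound 1 to compound 3 (0.35 log units; beyond the scatter). Compound 3 is therefore estimated at 150000000 nM, with a range from 40000000 nM to 500000000 nM.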

Compound 3, half-maximal inhibitory concentration: 67600000 nM
For compound 3 the middle estimate is 2.2-fold (0.35 log units) above the measured one, and the stated range covers the measured number.
By their numbers in this assay, from the lowest: compound 3; then compounds 2 and 1 (each within the scatter of the next).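

Placing pentyl on a saturated chain carbon, three bonds along the chain from a nitrogen on an aromatic ring, gives a 5.0-fold lower number from compound 1 to compound 3 (0.70 log units; beyond the scatter) in this assay and is the first change on this chain to go beyond the scatter. So this part of the chain does respond to modification, though only modestly. Nothing available explains the change.

As far as these compounds go, whether a longer chain would lower the number further remains open. So does what an amine or a carboxylic acid at the chain end would do.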